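The source may hold more compounds than are shown below. What is called first, only, known or untested is meant among the compounds shown, and "the series" means these compounds.

Measured so far in a functional assay on A549 cells (Homo sapiens) for inhibition, read by MTT assay, with a stated time of 72 h, tested at 10 uM; a lower number here means less inhibition, a higher number more inhibition at the concentration tested (going by the name of the read-out):
compound 1 `CCOC(=O)C1=C(Nc2ccccc2)S/C(=C\c2ccc(O)c(O)c2)C1=O` gives 30.7%;
compound 2 `CCOC(=O)C1=C(Nc2ccccc2)S/C(=C\c2cccc(C(=O)O)c2)C1=O` gives < 10%, which is a limit of the assay rather than a number, as noted in the limit of < 10% in this assay, at which 1 of the 3 values shown sits;
compound 3 `CCOC(=O)C1=C(Nc2ccccc2)S/C(=C\c2cc3cccnc3[nH]2)C1=O` gives 16.7%.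

Compound 3 thus holds the lowest of the two numbers shown; its nearest neighbour is compound 1, with the step of a number 14 percentage points lower from compound 1 to compound 3 (beyond the scatter). The comparison with compound 2 is given by a number at least 6.7 percentage points higher from compound 2 to compound 3 (that floor lies within the scatter).

Compound 4 `CCOC(=O)C1=C(Nc2ccccc2)S/C(=C\c2cc3ccncc3[nH]2)C1=O` differs from compound 3 only at the group on the double-bonded chain carbon: a group of 9 heavy atoms (7 carbon, 2 nitrogen; one five-membered aromatic ring with 1 hetero atom, one six-membered aromatic ring with 1 hetero atom) in place of a group of 9 heavy atoms (7 carbon, 2 nitrogen; one five-membered aromatic ring with 1 hetero atom, one six-membered aromatic ring with 1 hetero atom), on a double-bonded chain carbon bound to a double-bonded ring carbon. The same atoms are present, joined differently, so this is a smaller change than the two steps above, which swapped whole groups of different make-up. Neither of those steps moved the number far, and the smaller change here is expected to move it even less, so no step beyond the scatter is expected: a number 0.3 percentage points higher from compound 3 to compound 4 (within the scatter). The estimated read-out for compound 4 in this assay is 17%, with a range from 7% to 28%.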

Compound 4, a percentage reported as inhibition, at one concentration (the size of the read-out at that concentration, not a potency): 17.1%
For compound 4 the middle estimate is 0.1 percentage points below the measured one, within the range that was stated.
By their numbers in this assay, from the lowest: compounds 3 and 4 (each within the scatter of the next); then compound 1. At a limit, below all of these: compound 2.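

In this assay, the number is level when the same atoms are rearranged within the group on the double-bonded chain carbon: a number 0.4 percentage points higher from compound 3 to compound 4 (within the scatter). Within the data shown here, earlier steps swapped whole groups of different make-up, so this is the first sign that this finer change leaves the read-out in place, while the gap to the 3,4-dihydroxyphenyl compound appears again with a second group: a number 13.6 percentage points lower from compound 1 to compound 4 (beyond the scatter). One comparison is only a floor, set by a limit rather than a number: a number at least 7.1 percentage points higher from compound 2 to compound 4 (that floor lies within the scatter).

As far as these compounds go, it remains open whether the higher number of compound 1 needs both hydroxyl groups, which a 4-hydroxyphenyl or a 3,4-dimethoxyphenyl group at this position would test. Also open, from the compounds shown here alone, is whether the shared core would keep these numbers with a carboxylic acid in place of its ethyl ester.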